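The compounds below may be only part of what the source reports. "The series", "measured", "known", "first", "only" and "open" are said of these compounds alone.

Measured so far in a functional assay on HeLa cells (Homo sapiens) for cytotoxicity, read by MTT assay, with a stated time of 2 days; on this read-out lower numbers stand for higher toxicity in this test and higher numbers for lower toxicity in this test:
- compound 1 `COc1ccc(-c2cc3cc(-c4ccc(F)cc4)cc(C(C)=O)c3[nH]2)cc1`: 42800 nM
- compound 2 `COc1ccc(-c2cc(C(C)=O)c3[nH]c(-c4ccc(OC)cc4)cc3c2)cc1`: 7130 nM
- compound 3 `CC(=O)c1cc(/C=C/c2ccc(F)cc2)cc2cc(-c3ccc(F)cc3)[nH]c12`: 5680 nM

Among these three, compound 3 gives the lowest number, but compound 2 lies within the usual scatter of it, so the two cannot be ordered; only compound 1 sits clearly higher. Compound 4 `COc1ccc(-c2cc3cc(/C=C/c4ccc(F)cc4)cc(C(C)=O)c3[nH]2)cc1` has not yet been measured. It differs from compound 3 by one change: methoxy in place of fluoro on an aromatic carbon. The same exchange has already been seen once, between compound 1 and compound 2, where it gave a 6.0-fold lower number from compound 1 to compound 2 (0.78 log units; beyond the scatter). On that single precedent a lowering of similar size is expected here, a 4.7-fold lower number from compound 3 to compound 4 (0.68 log units; beyond the scatter). For compound 4 the estimate is therefore 1200 nM, with a range from 400 nM to 4000 nM.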

Compound 4, concentration lethal to 50% of the cells: 8770 nM
Compound 4: middle estimate off by 7.3-fold (0.86 log units), on the low side, outside the stated range (above it).
By their numbers in this assay, from the lowest: compounds 3, 2 and 4 (each within the scatter of the next); then compound 1.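

In this assay, methoxy in place of fluoro has no fixed effect at this position, and its size changes with the rest of the molecule: the same change on two cores in this assay, a 6.0-fold lower number (0.78 log units; beyond the scatter) from compound 1 to compound 2 and a 1.5-fold higher number (0.19 log units; within the scatter) from compound 3 to compound 4, 9.3-fold (0.97 log units) apart, beyond the scatter of two such steps With the 2-(4-fluorophenyl)ethenyl group present, the exchange gives a 1.5-fold higher number from compound 3 to compound 4 (0.19 log units; within the scatter), so no change can be claimed there. That same group in place of 4-methoxyphenyl gives a 1.2-fold higher number from compound 2 to compound 4 (0.09 log units; within the scatter), but in place of 4-fluorophenyl it gives a 4.9-fold lower number from compound 1 to compound 4 (0.69 log units; beyond the scatter), which leaves only compound 1 standing apart.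

The compounds shown give no cause for the two cores' different responses. As far as these compounds go, whether an amine or a carboxylic acid in place of fluoro or methoxy would move the number clearly remains open.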